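The source may report more compounds than this note shows. Statements on the series, on what has been measured and on what is new or still open speak of the compounds shown alone.

Measured compounds:
compound 1, `CCn1c(C(=O)NCC#N)ccc1C(CC)(CC)c1ccc(OCCC(O)(CC)CC)c(C)c1`, 1080 nM
compound 2, `CCn1c(C(=O)NCCN)ccc1C(CC)(CC)c1ccc(OCCC(O)(CC)CC)c(C)c1`, 156 nM
compound 3, `C#CCCOC(=O)c1ccc(C(CC)(CC)c2ccc(OCCC(O)(CC)CC)c(C)c2)n1CC`, 6030 nM

In an assay on cells for agonist activity at vitamin D3 receptor (Homo sapiens), with a stated time of 96 h (on this read-out lower numbers stand for an effect already at smaller amounts and higher numbers for an effect only at larger amounts of compound), compound 3 gives the highest of the three numbers; the nearest is compound 1, the furthest compound 2. Compound 4, `CCOC(=O)C(CC(=O)OC)NC(=O)c1ccc(C(CC)(CC)c2ccc(OCCC(O)(CC)CC)c(C)c2)n1CC`, is not yet measured. It differs from compound 3 by a group of 12 heavy atoms (7 carbon, 1 nitrogen, 4 oxygen; no ring) in place of a group of 5 heavy atoms (4 carbon, 1 oxygen; no ring), on a carbonyl carbon.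

Within the data shown here, two measured steps bear on this change, since both replace a group on the same carbonyl carbon. The step of a 5.6-fold higher number from compound 1 to compound 3 (0.75 log units; beyond the scatter) and the step of a 39-fold higher number from compound 2 to compound 3 (1.59 log units; beyond the scatter) both show that removing the (but-3-yn-1-yl)oxy group in favour of a nitrogen-linked group brings a lower number, modest in one case and large in the other. The entering group of compound 4 is nitrogen-linked but carries no aminomethyl, so the smaller of the two steps is the closer guide. A modest step toward lower numbers is therefore expected, a 4.0-fold lower number from compound 3 to compound 4 (0.60 log units; beyond the scatter). Compound 4 is estimated at 1500 nM, within a range from 400 nM to 6000 nM.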

Compound 4, half-maximal effective concentration: 21 nM
Compound 4: the middle estimate sits 71-fold (1.85 log units) above what was measured; the measured number lies below the stated range.
By their numbers in this assay, from the lowest: compound 4; then compound 2; then compound 1; then compound 3.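

In this assay, among these compounds, the nitrogen-linked group on this carbonyl carbon goes much further than the earlier compounds showed, with a 290-fold lower number from compound 3 to compound 4 (2.46 log units; beyond the scatter) exceeding both earlier steps away from the (but-3-yn-1-yl)oxy group. The larger ester-bearing group on the amide-type nitrogen also improves on both shorter chains, giving a 7.4-fold lower number from compound 2 to compound 4 (0.87 log units; beyond the scatter) and a 51-fold lower number from compound 1 to compound 4 (1.71 log units; beyond the scatter) and the lowest number of the four, so among these compounds the aminomethyl group is not needed to reach it. Nothing measured here accounts for these steps.

The compounds shown do not tell whether the ethyl ester, the methyl ester or both carry the gain. Nor do they show how this assay would read for a carboxylic acid in place of either ester or for a longer chain on the amide-type nitrogen.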